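A few compounds are considered here, and "the series" means these few. Any claim that something is new, unique, unknown or untested is made for them only; others in the source may bear on it.

Three compounds share one core and differ only in the group on a carbonyl carbon. In a functional assay on HCT-116 cells (Homo sapiens) for antiproliferative activity, read by resazurin assay, with a stated time of 5 days (on this read-out higher numbers stand for weaker inhibition and lower numbers for stronger inhibition), compound 1 (`Cc1ccc(C(=O)NCc2ccc3cc(C(=O)NO)sc3c2F)s1`) gives 120 nM, compound 2 (`Cc1cc(C(=O)NCc2ccc3cc(C(=O)NO)sc3c2F)oc1C`) gives 470 nM and compound 3 (`O=C(NCc1ccc2cc(C(=O)NO)sc2c1F)c1ccc[nH]1`) gives 300 nM. The data show a 1.6-fold lower number from compound 2 to compound 3 (0.19 log units; within the scatter), so these two cannot be told apart. They also show a 2.5-fold higher number from compound 1 to compound 3 (0.40 log units; beyond the scatter). Compound 3 therefore sits level with compound 2 and falls short of compound 1.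

Compound 4 (`O=C(NCc1ccc2cc(C(=O)NO)sc2c1F)c1ccccc1`) carries phenyl in place of 1H-pyrrol-2-yl on a carbonyl carbon. Going by the values given here, no measured compound carries phenyl, so the only guide is how far changes at this carbonyl carbon have moved the number. The largest move so far is a 3.9-fold higher number from compound 1 to compound 2 (0.59 log units; beyond the scatter), which is modest. A similar move in either direction is possible, but no clear shift is expected, and the direction remains uncertain. The expected change is a 1.2-fold lower number from compound 3 to compound 4 (0.08 log units; within the scatter). For compound 4 the estimated value is 250 nM, with an expected range from 90 nM to 650 nM.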

Compound 4, half-maximal inhibitory concentration: 980 nM
Estimate against measurement, compound 4: 3.9-fold (0.59 log units) below, outside the stated range (above it).
By their numbers in this assay, from the lowest: compound 1; then compounds 3 and 2 (each within the scatter of the next); then compound 4.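

In this assay, going by these compounds alone, the group on the carbonyl carbon matters more than the earlier compounds showed: phenyl gives a 3.3-fold higher number from compound 3 to compound 4 (0.51 log units; beyond the scatter) and a 2.1-fold higher number from compound 2 to compound 4 (0.32 log units; beyond the scatter) and an 8.2-fold higher number from compound 1 to compound 4 (0.91 log units; beyond the scatter) as the widest step so far. All three steps lie beyond the scatter, so compound 4, the only one here with a six-membered aromatic ring of carbon only, is the weakest of the four, while the three five-membered aromatic rings all give lower numbers. Nothing measured here gives a reason for this gap.

Phenyl differs from the five-membered rings both in ring size and in carrying no hetero atom, and these compounds do not separate the two. As far as these compounds go, how a pyridin-2-yl group, a six-membered aromatic ring holding a nitrogen, or a phenyl carrying a methyl group would fare at this position stays open.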